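This account rests on a few compounds, and the source may have more. Where it says the series, first, only, none or still open, it means among the compounds named here.

Compound 2 `C/C(=N\NC(=O)c1cccc(S(=O)(=O)N2CCOCC2)c1)c1ccccc1O` stands at the strongest end of the two numbers recorded in a functional assay on MGC-803 cells (Homo sapiens) for antiproliferative activity, read by MTT assay, with a stated time of 72 h (a lower number here means a stronger inhibitor, a higher number a weaker inhibitor), where compound 2 gives 1220 nM. Compound 3 `C/C(=N\NC(=O)c1cccc(S(=O)(=O)N2CCOCC2)c1)c1ccc(O)cc1` gives 71400 nM in this assay. Compound 1 `C/C(=N\NC(=O)c1cccc(S(=O)(=O)N2CCOCC2)c1)c1ccc(F)cc1` is recorded in this assay only as > 100000 nM, which is a limit and not a number (the limit of > 100000 nM in this assay, at which 1 of the 3 values shown sits). The measured steps show an at least 81-fold lower number from compound 1 to compound 2 (1.91 log units; beyond the scatter) and a 59-fold higher number from compound 2 to compound 3 (1.77 log units; beyond the scatter), while an at least 1.4-fold lower number from compound 1 to compound 3 (0.14 log units; that floor lies within the scatter) is a floor within the scatter.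

Compound 4 `C/C(=N\NC(=O)c1cccc(S(=O)(=O)N2CCOCC2)c1)c1cc(O)ccc1O` differs from compound 2 by hydroxy in place of hydrogen on an aromatic carbon, para to a hydroxy group, so that 2-hydroxyphenyl becomes 2,5-dihydroxyphenyl. The 2-hydroxyphenyl that separates compound 2 from compound 3 is kept. For the measured compounds named here, no measured step adds a second hydroxy to that ring, so the expectation rests on the kept group alone, and a modest change is expected, a 1.6-fold higher number from compound 2 to compound 4 (0.21 log units; within the scatter). Compound 4 is therefore expected to give about 2000 nM in this assay, within a range from 600 nM to 8000 nM.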

Compound 4, half-maximal inhibitory concentration: 9090 nM
For compound 4 the middle estimate is 4.5-fold (0.66 log units) below the measured one; the measured number lies above the stated range.
By their numbers in this assay, from the lowest: compound 2; then compound 4; then compound 3. At a limit, above all of these: compound 1.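

Adding a second hydroxy to the 2-hydroxyphenyl ring of compound 2, at the place para to a hydroxy group, is not a neutral change in this assay: the step is a 7.5-fold higher number from compound 2 to compound 4 (0.87 log units; beyond the scatter). The 2,5-dihydroxyphenyl ring still keeps much of the advantage of the 2-hydroxyphenyl ring over the 4-hydroxyphenyl ring, with a 7.9-fold lower number from compound 3 to compound 4 (0.90 log units; beyond the scatter), so the second hydroxy gives back only part of what the first one's placement brings. Against the 4-fluorophenyl ring the step is an at least 11-fold lower number from compound 1 to compound 4 (1.04 log units; beyond the scatter), which is only a floor, as compound 1 is held at a limit: the limit of > 100000 nM in this assay, at which 1 of the 4 values shown sits.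

From the compounds shown here alone, it remains open whether a methoxy group, a chlorine or an amine at this same place would give a similar loss or none. Also open, going by these compounds, is whether an amine could stand in for the 2-hydroxy group itself.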